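Biphenyl in Place of Bromophenyl on the Sulfonyl Sulfur

This account rests on a few compounds, and the source may have more. Where it says the series, first, only, none or still open, it means among the compounds named here.

In a functional assay on DLD-1 cells (Homo sapiens) for antiproliferative activity, read by CellTiter-Glo, with a stated time of 72 h (on this read-out lower numbers stand for stronger inhibition and higher numbers for weaker inhibition), compound 1 `CC1CCN(C2CCN(S(=O)(=O)c3cccc(Br)c3)CC2)CC1` gives 3.2 nM, the highest of the two plain numbers; the nearest is compound 2 `Cc1nc(Cl)sc1S(=O)(=O)N1CCC(N2CCC(C)CC2)CC1` with 1.6 nM, a step of a 2.0-fold lower number from compound 1 to compound 2 (0.30 log units; within the scatter). Compound 3 `CC1CCN(C2CCN(S(=O)(=O)c3cncc(Br)c3)CC2)CC1` reaches only a limit, > 5000 nM. The move from compound 1 to compound 3 is an at least 1500-fold higher number from compound 1 to compound 3 (3.19 log units; beyond the scatter), and from compound 2 to compound 3 it is an at least 3100-fold higher number from compound 2 to compound 3 (3.49 log units; beyond the scatter), the evidence being (the limit of > 5000 nM in this assay, at which 1 of the 3 values shown sits). Compound 4 `CC1CCN(C2CCN(S(=O)(=O)c3cccc(-c4ccccc4)c3)CC2)CC1` differs from compound 1 in one place: phenyl in place of bromo on an aromatic carbon. Among the measured compounds shown here, no measured step swaps a single group on the same carbon ring; the measured steps replace the whole ring on the sulfonyl sulfur, and they show that this part of the molecule can shift the number either slightly or far beyond the scatter. A phenyl in place of the bromo keeps the ring of compound 1 intact, so a moderate change in either direction is expected, a 3.1-fold higher number from compound 1 to compound 4 (0.49 log units; beyond the scatter). Compound 4 is estimated at 10 nM, between 2 nM and 100 nM.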

Compound 4, half-maximal inhibitory concentration: 2 nM
Compound 4: middle estimate off by 5.0-fold (0.70 log units), on the high side; the measured number falls inside the stated range.
By their numbers in this assay, from the lowest: compounds 2, 4 and 1 (each within the scatter of the next). At a limit, above all of these: compound 3.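

In this assay the swap of bromo for phenyl gives a 1.6-fold lower number from compound 1 to compound 4 (0.20 log units; within the scatter), so this aromatic carbon, meta to a large group, carries either a single bromine or a phenyl with its 6 heavy atoms and its own aromatic ring, and the two compounds cannot be told apart. The earlier steps shown here replaced the whole ring on the sulfonyl sulfur, whereas this one leaves that ring in place and changes only the group on it, which shows that a far larger group at this position need not cost activity. Nothing shown here accounts for why the two groups read alike.

Going by these compounds, it remains open whether an amine, a carboxylic acid or a longer alkyl chain on this carbon would read the same way. Also open, on these data alone, is whether a phenyl bearing its own substituents would still fall within the scatter of compound 1.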